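Ethoxycarbonyl in place of fluoro on the shared core

This account rests on a few compounds, and the source may have more. Where it says the series, first, only, none or still open, it means among the compounds named here.

Of the compounds shown here, three on a shared core have been measured in a functional assay on SMMC-7721 cells (Homo sapiens) for cytotoxicity, read by MTT assay, with a stated time of 72 h; on this read-out higher numbers stand for weaker inhibition and lower numbers for stronger inhibition. Compound 1, `Cc1ccc(NC(=O)CSC(=S)N[C@H]2CCOC2=O)cc1`, gives 32700 nM in this assay. Compound 2, `COc1ccc(NC(=O)CSC(=S)N[C@H]2CCOC2=O)cc1`, gives only a limit of the assay in this assay, > 128000 nM. Compound 3, `O=C(CSC(=S)N[C@H]1CCOC1=O)Nc1ccc(F)cc1`, likewise gives only a limit in this assay, > 128000 nM. The change an at least 3.9-fold higher number from compound 1 to compound 2 (0.59 log units; beyond the scatter) and the change an at least 3.9-fold higher number from compound 1 to compound 3 (0.59 log units; beyond the scatter) are both at least modest, while a step that the two limits leave unreadable from compound 2 to compound 3. Compound 3 thus stands at the top of the numbers shown, sharing that position because of the limit of > 128000 nM in this assay, at which 2 of the 3 values shown sit.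

Compound 4 is `CCOC(=O)c1ccc(NC(=O)CSC(=S)N[C@H]2CCOC2=O)cc1`. Its difference from compound 3 is ethoxycarbonyl in place of fluoro on an aromatic carbon. For the measured compounds named here, no measured step here exchanges an ethoxycarbonyl for anything, and the two readable steps only show that leaving methyl for fluoro or methoxy raised the number. The step of a number no higher from compound 3 to compound 4 (the limit leaves the size open) is therefore expected to stay within the scatter, from a starting point that is itself a limit. Compound 4 is estimated at 128000 nM in this assay, between 30000 nM and 400000 nM.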

Compound 4, half-maximal inhibitory concentration: 64900 nM
Compound 4: middle estimate off by 2.0-fold (0.29 log units), on the high side, within the range that was stated.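

For the compounds shown here, at this position, para to a large group, compound 4 with its ethoxycarbonyl is the only compound besides compound 1 to give a measured number rather than a limit in this assay: the limit of > 128000 nM in this assay, at which 2 of the 4 values shown sit. Set against those limits, the exchange gives an at least 1.9-fold lower number from compound 3 to compound 4 (0.29 log units; that floor lies within the scatter), and the exchange for methoxy gives an at least 1.9-fold lower number from compound 2 to compound 4 (0.29 log units; that floor lies within the scatter), so the true size of each step stays open. Against methyl the exchange gives a 2.0-fold higher number from compound 1 to compound 4 (0.30 log units; within the scatter), so this assay does not separate ethoxycarbonyl from methyl at this position.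

The compounds shown leave open whether a carboxylic acid, an amine or a longer alkoxycarbonyl chain at this position would give a number on the same level as compound 4. From the compounds shown here alone, how far compound 2 and compound 3 truly lie from compound 4 also remains unknown.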